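A few compounds are considered here, and "the series" means these few. Any claim that something is new, unique, unknown or untested is made for them only; others in the source may bear on it.

Measured so far:
compound 1, `Cc1ccnc(/C(N)=N/NC(=S)N2CCN(c3ccccn3)CC2)c1`, gives 79.4% in a functional assay on A-375 cells (Homo sapiens) for cytotoxicity, read by MTT assay, with a stated time of 72 h, tested at 30 uM; a higher number here means more inhibition of growth at the concentration tested, a lower number less inhibition of growth.
compound 2, `Cc1cccc(/C(N)=N/NC(=S)N2CCCC2)n1`, gives 60.8% in this assay.
compound 3, `N/C(=N\NC(=S)N1CCCC1)c1ccccn1`, gives 86% in this assay.

Compound 2 and compound 3 share one core and differ in a single spot: hydrogen in place of methyl on an aromatic carbon. In this assay this gave a number 25.2 percentage points higher from compound 2 to compound 3 (beyond the scatter). Compound 1 sits on a different core; how its core differs from that of compound 2 is not broken down here. Compared with compound 2, compound 1 gives a number beyond the scatter higher, while compound 1 and compound 3 give numbers within the scatter of each other, so no order between those two can be read from the data.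

Compound 4, `N/C(=N\NC(=S)N1CCN(c2ccccn2)CC1)c1ccccn1`, has not yet been measured. It differs from compound 1 by hydrogen in place of methyl on an aromatic carbon. For the measured compounds named here, this is the same kind of change as the one from compound 2 to compound 3, but not the same: in compound 2 the methyl sits next to the ring nitrogen, whereas in compound 1 it sits opposite the ring nitrogen; in both it is meta to a large group. The earlier step was modest in size, and a smaller step is expected here because compound 1 already gives 79.4%, leaving little room above it. For compound 4 the expected value in this assay is 88%, with a likely range from 76% to 97%. Going by the values given here, this estimate means for compound 4 an expected step of a number 8.6 percentage points higher from compound 1 to compound 4 (within the scatter), which rests on the single earlier step and on the fact that the place of the change is not the same.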

Compound 4, percent growth inhibition at one concentration: 81%
For compound 4 the middle estimate is 7 percentage points above the measured one; low and high end bracket the measured number.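

Taking the methyl off the aromatic ring gives a number 1.6 percentage points higher from compound 1 to compound 4 (within the scatter) in this assay, so on this core the exchange of methyl for hydrogen produces no step that can be told apart from ordinary repeat variation. For the compounds shown here, this shows that the size of the step on one core cannot simply be assumed on another, but it does not show what sets the two steps apart: only two pairs are available, and they differ both in the rest of the molecule and in where the methyl stands, since in compound 1 it sits opposite the ring nitrogen and in compound 2 it does not. A newly measured pair can therefore change the picture considerably, and the comparison of the two steps reads as follows: the same change on two cores in this assay, a number 25.2 percentage points higher (beyond the scatter) from compound 2 to compound 3 and a number 1.6 percentage points higher (within the scatter) from compound 1 to compound 4, 23.6 percentage points apart, beyond the scatter of two such steps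

Still open, on these data alone, is how a methyl opposite the ring nitrogen would behave on the core of compound 3, a comparison that could separate the influence of the core from that of the place on the ring. Also open, as far as these compounds go, is how a different group at that place, such as an ethyl, a methoxy or an amine, would compare with hydrogen on either core.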